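The compounds below may be only part of what the source reports. "The series", "measured", "known", "first", "only" and "open" are said of these compounds alone.

Measured compounds in this series:
compound 1 `C=CC[C@@]12CCN[C@@H]1n1c3nc4ccc(OC)cc4cc3c(=O)c3cccc2c31`, 14800 nM
compound 2 `COc1ccc2nc3c(cc2c1)c(=O)c1cccc2c1n3[C@H]1NCC[C@@]21CCO`, 1400 nM
compound 3 `C=CC[C@@]12CCN(C(=O)OC(C)(C)C)[C@@H]1n1c3nc4ccc(O)cc4cc3c(=O)c3cccc2c31`, 30500 nM

All three were tested in a functional assay on HeLa cells (Homo sapiens) for inhibition, read by trypan blue exclusion, with a stated time of 72 h; on this read-out higher numbers stand for weaker inhibition of growth and lower numbers for stronger inhibition of growth. Compound 2 carries hydroxymethyl in place of vinyl on a saturated chain carbon bound to a saturated ring carbon relative to compound 1, and this change gave an 11-fold lower number from compound 1 to compound 2 (1.02 log units; beyond the scatter). Compound 3 stands with the highest number of the three; how its core differs from that of compound 1 is not broken down here.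

Compound 4 `CC(C)(C)OC(=O)N1CC[C@@]2(CCO)c3cccc4c(=O)c5cc6cc(O)ccc6nc5n(c34)[C@@H]12` has not yet been measured. It differs from compound 3 by hydroxymethyl in place of vinyl on a saturated chain carbon bound to a saturated ring carbon, the same change as that from compound 1 to compound 2, at the same kind of place. Resting on the single earlier step of an 11-fold lower number from compound 1 to compound 2 (1.02 log units; beyond the scatter), compound 4 is expected to show a step of an 8.7-fold lower number from compound 3 to compound 4 (0.94 log units; beyond the scatter) in this assay. The estimate for compound 4 is 3500 nM, with an expected range from 1000 nM to 12000 nM; one prior example gives limited support for carrying the step across cores.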

Compound 4, concentration for 50% growth inhibition: 13000 nM
For compound 4 the middle estimate is 3.7-fold (0.57 log units) below the measured one; measured number outside the range, above it.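

In this assay, hydroxymethyl in place of vinyl on a saturated chain carbon bound to a saturated ring carbon gives a 2.3-fold lower number from compound 3 to compound 4 (0.37 log units; beyond the scatter). The direction of the change carries over to the second core, but its size does not: the same change on two cores in this assay, an 11-fold lower number (1.02 log units; beyond the scatter) from compound 1 to compound 2 and a 2.3-fold lower number (0.37 log units; beyond the scatter) from compound 3 to compound 4, 4.5-fold (0.65 log units) apart, beyond the scatter of two such steps. These two pairs do not show which of the differences between the cores goes with the smaller step, and they give no rule for predicting the size of the step on a further core.

Still open, on these data alone, is how an amine or a carboxylic acid at the same place, or a longer chain, would read in this assay. Also open, as far as these compounds go, is whether either would keep the same direction on both cores.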